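Chloro for Trifluoromethyl on the Diaryl Urea Tail

The source may report more compounds than this note shows. Statements on the series, on what has been measured and on what is new or still open speak of the compounds shown alone.

Compound 1 `COc1cc2cc(Oc3ccc(NC(=O)Nc4ccccc4)cc3)c(C)nc2cc1OC` and compound 2 `COc1cc2cc(Oc3ccc(NC(=O)Nc4ccc(Cl)c(C(F)(F)F)c4)cc3)c(C)nc2cc1OC` share a core and differ only at the outer ring of the urea. In a functional assay on PC-3 cells (Homo sapiens) for inhibition, read by sulforhodamine B assay, with a stated time of 48 h, tested at 10 uM (on this read-out lower numbers stand for a stronger effect and higher numbers for a weaker effect at the one concentration tested), compound 1 gives 60.4%, whereas compound 2 gives -0.61%. For the measured compounds named here, the single measured step, a number 61 percentage points lower from compound 1 to compound 2 (beyond the scatter), is therefore the whole basis for reading this series, and it places compound 2 as the lowest of the two numbers in this assay, with compound 1 as its only neighbour.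

Compound 3 `COc1cc2cc(Oc3ccc(NC(=O)Nc4ccc(Cl)c(Cl)c4)cc3)c(C)nc2cc1OC` differs from compound 2 by chloro in place of trifluoromethyl on an aromatic carbon, so that the 4-chloro-3-(trifluoromethyl)phenyl becomes a 3,4-dichlorophenyl. Going by the values given here, the one step that bears on this, the large move from compound 1 to compound 2, shows that substitution of this ring with a chloro and a trifluoromethyl group carries a strong effect; no measured step separates the two groups from each other. On that ground compound 3 is expected to stay close to compound 2, and the step of a number 10.6 percentage points higher from compound 2 to compound 3 (beyond the scatter) is estimated to remain within the scatter. Compound 3 is therefore estimated at 10%, with a range from -10% to 35%.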

Compound 3, a percentage reported as activity, at one concentration (the size of the read-out at that concentration, not a potency): 4.12%
The estimate for compound 3 lay 5.9 percentage points above the measured number; the measured number falls inside the stated range.
By their numbers in this assay, from the lowest: compounds 2 and 3 (each within the scatter of the next); then compound 1.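

In this assay, chloro in place of trifluoromethyl on this aromatic carbon gives a number 4.7 percentage points higher from compound 2 to compound 3 (within the scatter), so the group of four heavy atoms can give way to one of a single heavy atom without a difference that can be told from the scatter. The large effect of substituting the outer ring therefore does not require the trifluoromethyl group: with 3,4-dichlorophenyl in place of phenyl, the read-out shows a number 56.3 percentage points lower from compound 1 to compound 3 (beyond the scatter), and this step is beyond the scatter, as is the one to the 4-chloro-3-(trifluoromethyl)phenyl compound. No measurement is available to explain why the two groups read alike on this aromatic carbon.

The compounds shown leave open whether the retained chloro alone would carry the effect, since each active compound here holds two substituents on the outer ring. They also leave open how a nitrile, a methoxy group or an amine would read on the same aromatic carbon, and whether compound 2 and compound 3 would stay together at other concentrations.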